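Swapping a fluorophenyl for a pyridinyl ring beside the carbonyl

The source may report more compounds than this note shows. Statements on the series, on what has been measured and on what is new or still open speak of the compounds shown alone.

Measured so far:
Compound 1, `CN(C)C(=S)SCC(CSC(=S)N(C)C)C(=O)c1ccc(F)cc1`: 1210 nM
Compound 2, `CN(C)C(=S)SCC(CSC(=S)N(C)C)C(=O)c1ccc(OCc2ccccc2)cc1`: 9770 nM

Both compounds were tested in a functional assay on NCI-H460 cells (Homo sapiens) for inhibition, read by MTT assay, with a stated time of 72 h; a higher number here means a weaker inhibitor, a lower number a stronger inhibitor. Going by the values given here, compound 1 gives the lower of the two numbers, and the only change made so far sits on the aromatic ring: an 8.1-fold higher number from compound 1 to compound 2 (0.91 log units; beyond the scatter). Compound 3, `CN(C)C(=S)SCC(CSC(=S)N(C)C)C(=O)c1cccnc1`, has not yet been measured. It differs from compound 1 as follows: pyridin-3-yl in place of 4-fluorophenyl on a carbonyl carbon.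

Among the compounds with values here, the one known step, from compound 1 to compound 2, touches the same aromatic ring but changes a different part of it, so it bears on the new change only loosely. It shows that altering this ring does move the read-out, and that the shift was modest rather than large. A change of the whole ring to pyridin-3-yl is therefore expected to give, at most, a small to modest step, with a weaker inhibitor somewhat more likely than a stronger one. The expected step is a 1.8-fold higher number from compound 1 to compound 3 (0.26 log units; within the scatter). Compound 3 is estimated at 2200 nM, with a range from 700 nM to 7000 nM.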

Compound 3, half-maximal inhibitory concentration: 870 nM
Compound 3: the middle estimate sits 2.5-fold (0.40 log units) above what was measured, and the stated range covers the measured number.
By their numbers in this assay, from the lowest: compounds 3 and 1 (each within the scatter of the next); then compound 2.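

In this assay putting pyridin-3-yl in place of 4-fluorophenyl on a carbonyl carbon gives a 1.4-fold lower number from compound 1 to compound 3 (0.14 log units; within the scatter) and so leaves the two compounds indistinguishable in this read-out. Going by these compounds alone, the only earlier change at this ring, benzyloxy in place of fluoro, gave an 8.1-fold higher number from compound 1 to compound 2 (0.91 log units; beyond the scatter) and showed that the number can rise beyond the scatter; the new result shows that not every change here does so, since a ring holding a nitrogen and no fluorine sits at this place with no step beyond the scatter. The data shown offer no explanation for either step.

This swap removes the fluorine and brings in the ring nitrogen at once, so a plain phenyl group would be needed to separate the two changes, and the result cannot say what either one does alone. Also open, on these data alone, is how the number responds to an amine or a carboxylic acid on the aromatic ring, or to a longer saturated chain on the carbonyl carbon in place of the ring.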